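Methoxy to dimethylamino in a piperidine-amide diene series

This account rests on a few compounds, and the source may have more. Where it says the series, first, only, none or still open, it means among the compounds named here.

Measured so far:
compound 1, `CN(C)c1ccc(/C=C/C=C/C(=O)N2CCCCC2)cc1`, gives 13.4% in an assay for inhibition of Polyunsaturated fatty acid 5-lipoxygenase (Homo sapiens), read by spectrophotometry, tested at 20 uM; on this read-out higher numbers stand for more inhibition at the one concentration tested (going by the name of the read-out) and lower numbers for less inhibition
compound 2, `COc1ccc(/C=C/C=C/C=C/C(=O)N2CCCCC2)cc1`, gives 1.08% in this assay
compound 3, `COc1ccc(/C=C/C=C/C(=O)N2CCCCC2)cc1`, gives 42.6% in this assay

Compound 3 carries the highest number of the three, and compound 2 the lowest. How the core of compound 2 differs from that of compound 3 is not broken down here. Within the shorter core, the change dimethylamino in place of methoxy on an aromatic carbon gave the step of a number 29.2 percentage points lower from compound 3 to compound 1 (beyond the scatter).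

Compound 4, `CN(C)c1ccc(/C=C/C=C/C=C/C(=O)N2CCCCC2)cc1`, is not yet measured. It relates to compound 2 by dimethylamino in place of methoxy on an aromatic carbon, the same change made from compound 3 to compound 1. Because compound 2 already stands at 1.08%, near the bottom of the scale, a downward step of the earlier size has no room to appear; the expected step is a number 0.1 percentage points lower from compound 2 to compound 4 (within the scatter). Compound 4 is therefore estimated at 1%, with the range -9% to 11%.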

Compound 4, a percentage reported as inhibition, at one concentration (the size of the read-out at that concentration, not a potency): 27.4%
For compound 4 the middle estimate is 26.4 percentage points below the measured one; the measured number lies above the stated range.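

In this assay, dimethylamino in place of methoxy on the longer core gives a number 26.3 percentage points higher from compound 2 to compound 4 (beyond the scatter) and so raises the number where the shorter core lowered it. For the compounds shown here, this rests on one pair per core and shows only that a step read on one of these two cores does not predict the step on the other; it gives no reason for the reversal and no rule for any further core. The change therefore does not carry over between these cores in direction: the same change on two cores in this assay, a number 29.2 percentage points lower (beyond the scatter) from compound 3 to compound 1 and a number 26.3 percentage points higher (beyond the scatter) from compound 2 to compound 4, 55.5 percentage points apart, beyond the scatter of two such steps

Still open, from the compounds shown here alone, is whether the reversal extends to a hydroxyl group or a primary amine in place of methoxy, or to a chain longer than that of compound 2. Also open, going by these compounds, is whether it survives with morpholine in place of piperidine at the amide.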